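Extending the nitrile to a cyanovinyl group on the shared core

A few compounds are considered here, and "the series" means these few. Any claim that something is new, unique, unknown or untested is made for them only; others in the source may bear on it.

Compound 2 `Cc1cc(C#N)cc(C)c1Oc1ccnc(Nc2ccc(CN3CCN(S(=O)(=O)C(C)C)CC3)cc2)n1` is examined in an ADME assay on MT4 cells (Homo sapiens) for cytotoxicity, read by MTT assay (on this read-out higher numbers stand for lower toxicity in this test and lower numbers for higher toxicity in this test), where compound 2 gives 4540 nM. This is the higher of the two numbers available, and its nearest neighbour is compound 1 `Cc1cc(/C=C/C#N)cc(C)c1Oc1ccnc(Nc2ccc(CN3CCN(S(=O)(=O)N(C)C)CC3)cc2)n1`, which in this assay gives 3070 nM; the two values lie within the usual scatter, so no order between them can be read. The step to compound 3 `Cc1cc(/C=C/C#N)cc(C)c1Oc1ccnc(Nc2ccc(CN3CCN(S(=O)(=O)C(C)C)CC3)cc2)n1` changes a single place on the shared core: 2-cyanoethenyl in place of cyano on an aromatic carbon. Going by the values given here, compound 1 and compound 2 differ in two places, so no single step in this assay is known for the change in question, and the two values show only that both compounds fall close together. Compound 3 is therefore expected to stay near compound 2, with a step of a 1.3-fold lower number from compound 2 to compound 3 (0.10 log units; within the scatter) that is not expected to exceed the scatter. The estimate for compound 3 in this assay is 3600 nM, within a range from 1500 nM to 8500 nM.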

Compound 3, half-maximal cytotoxic concentration: 3810 nM
Beside the measured number, compound 3's estimate is 1.1-fold (0.02 log units) below it, and the stated range covers the measured number.
By their numbers in this assay, from the lowest: compounds 1, 3 and 2 (each within the scatter of the next).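

In this assay, going by these compounds alone, the first comparison confined to this aromatic carbon gives a 1.2-fold lower number from compound 2 to compound 3 (0.08 log units; within the scatter) and shows that 2-cyanoethenyl in place of cyano stays within the scatter on this read-out. The sulfonyl sulfur, which compound 1 and compound 2 could not separate from this position, now has its own comparison: isopropyl in place of dimethylamino gives a 1.2-fold higher number from compound 1 to compound 3 (0.09 log units; within the scatter) and also stays within the scatter. Each of the two places that differ between compound 1 and compound 2 thus stays within the scatter when taken alone, and no supporting measurement is available to account for this.

Going by these compounds, whether a carboxylic acid or an amine on this aromatic carbon would stay within the scatter remains open. The same holds for a longer chain on the sulfonyl sulfur.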